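A few compounds are considered here, and "the series" means these few. Any claim that something is new, unique, unknown or untested is made for them only; others in the source may bear on it.

In an ADME assay on HEK293 cells (Homo sapiens) for cytotoxicity, read by sulforhodamine B assay, with a stated time of 48 h, tested at 10 uM (on this read-out higher numbers stand for more inhibition at the one concentration tested (going by the name of the read-out) and lower numbers for less inhibition), compound 1 `CCCCc1cn(C(c2ccccc2)c2cc3cc(Br)ccc3nc2OC)nn1` gives -3.47%, while compound 2 `COc1nc2ccc(Br)cc2cc1C(c1ccccc1)n1cc(CCCO)nn1` gives 27.4%, the higher of the two numbers; the two are separated by a number 30.9 percentage points higher from compound 1 to compound 2 (beyond the scatter). Compound 3 `COc1nc2ccc(Br)cc2cc1C(c1ccccc1)n1cc(-c2ccccc2C(F)(F)F)nn1` differs from compound 2 by 2-(trifluoromethyl)phenyl in place of 3-hydroxypropyl on an aromatic carbon. Among the compounds with values here, no measured step exchanges a chain for an aromatic ring, so only the hydroxy step offers guidance, and it raised the number. Since the hydroxy behind a number 30.9 percentage points higher from compound 1 to compound 2 (beyond the scatter) now leaves, the number for compound 3 is expected to fall, by an estimated a number 15.4 percentage points lower from compound 2 to compound 3 (beyond the scatter). Compound 3 is estimated at 12%, within -15% to 40%.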

Compound 3, a percentage reported as inhibition, at one concentration (the size of the read-out at that concentration, not a potency): 14.3%
Beside the measured number, compound 3's estimate is 2.3 percentage points below it; the measured number falls inside the stated range.
By their numbers in this assay, from the lowest: compound 1; then compound 3; then compound 2.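

At this aromatic carbon, a hydroxy group is not needed for a number above that of the butyl compound: exchanging butyl for 2-(trifluoromethyl)phenyl gives a number 17.8 percentage points higher from compound 1 to compound 3 (beyond the scatter) in this assay. Exchanging 3-hydroxypropyl for the same aromatic group gives a number 13.1 percentage points lower from compound 2 to compound 3 (beyond the scatter), so this group falls between the two chains. No supporting measurement is available to explain either step. Still open, as far as these compounds go, is how plain phenyl, an amine or a carboxylic acid would compare at this carbon, and whether a longer chain ending in hydroxy would differ from 3-hydroxypropyl.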